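The source may hold more compounds than are shown below. What is called first, only, known or untested is meant among the compounds shown, and "the series" means these compounds.

Compound 3, `COc1ccc(-c2cnc(NC(=O)c3ccccc3)n2C)cc1`, stands alongside compound 1, `COc1ccc(-c2cnc(NC(=O)c3ccccn3)n2C)cc1`, and compound 2, `COc1ccc(-c2cnc(NC(=O)c3cccc(Br)c3)n2C)cc1`, in a toxicity assay on THP-1 cells (Homo sapiens) for inhibition; on this read-out lower numbers stand for higher toxicity in this test and higher numbers for lower toxicity in this test. In this assay compound 3 gives only a limit of > 100000 nM. Compound 1 likewise gives only a limit of > 100000 nM. Compound 2 also gives only a limit of > 100000 nM. The three steps between them, a step that the two limits leave unreadable from compound 1 to compound 2, a step that the two limits leave unreadable from compound 1 to compound 3 and a step that the two limits leave unreadable from compound 2 to compound 3, cannot be read, because of the limit of > 100000 nM in this assay, at which 3 of the 3 values shown sit. Compound 4, `COc1ccc(-c2cnc(NC(=O)c3ccccc3C#N)n2C)cc1`, is not yet measured; it differs from compound 3 by cyano in place of hydrogen on an aromatic carbon. The measured steps, which put 3-bromophenyl or phenyl in place of pyridin-2-yl on the carbonyl carbon or hydrogen in place of bromo on an aromatic carbon, bear on it only in showing that none of those changes brought a reading inside the measurable range. Among the compounds with values here, no step gives a size in either direction. The step of a number no higher from compound 3 to compound 4 (the limit leaves the size open) is therefore expected to remain unreadable. Compound 4 is estimated at 100000 nM, with a range from 40000 nM to 300000 nM, and is most likely to be reported as a limit as well.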

Compound 4, half-maximal cytotoxic concentration: > 100000 nM
Compound 4 was reported as a limit; the forecaster's own chance of this, stated with the estimate: 85%; the middle value sits exactly at the limit.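

In this assay the steps from compound 1, compound 2 and compound 3 to compound 4 cannot be read, because all four compounds give only a limit: the limit of > 100000 nM in this assay, at which 4 of the 4 values shown sit.

The compounds shown leave open whether any change to the group on the carbonyl carbon alters the read-out in this assay, and by how much.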